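Dimethylamino in place of hydroxy on the shared core

This account rests on a few compounds, and the source may have more. Where it says the series, first, only, none or still open, it means among the compounds named here.

Within the data shown here, in a functional assay on HCT-116 cells (Homo sapiens) for inhibition (on this read-out lower numbers stand for stronger inhibition and higher numbers for weaker inhibition), compound 1 `Oc1ccc(/C=C/c2ccc3ccccc3c2)cc1` gives 4060 nM as the only actual number so far. Compound 2 `FC(F)(F)c1ccc(/C=C\c2ccc3ccccc3c2)cc1` gives > 5000 nM in this assay and that value is a limit of the assay, not a number. Among the measured compounds shown here, no measured step is available yet.

Compound 3 `CN(C)c1ccc(/C=C/c2ccc3ccccc3c2)cc1` carries dimethylamino in place of hydroxy on an aromatic carbon, para to a large group: dimethylamino in place of hydroxy on an aromatic carbon on the core of compound 1.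

With compound 1 at 4060 nM as the sole reference, no change beyond the scatter is expected in this assay and no direction is favoured. The expected step is a 1.1-fold lower number from compound 1 to compound 3 (0.03 log units; within the scatter) and it should stay small. The estimate for compound 3 is 3800 nM with an expected range from 1500 nM to 9000 nM.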

Compound 3, half-maximal inhibitory concentration: 3660 nM
Beside the measured number, compound 3's estimate is 1.0-fold (0.02 log units) above it, within the range that was stated.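

In this assay, dimethylamino in place of hydroxy gives a 1.1-fold lower number from compound 1 to compound 3 (0.05 log units; within the scatter). This first measured step shows that, on this aromatic carbon para to a large group, the read-out stays within the scatter when the hydrogen-bond donor of hydroxy leaves and the larger dimethylamino enters. Compound 2 stays out of the comparison, as it differs from the others in more than one place and its value is a limit of the assay, not a number: the limit of > 5000 nM in this assay, at which 1 of the 3 values shown sits.

On these data alone, whether a carboxylic acid, a primary amine or a longer alkoxy chain at this position would shift the number beyond the scatter remains open. Also open, as far as these compounds go, is whether any group here can bring the number well under those of compound 1 and compound 3.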